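The source may hold more compounds than are shown below. What is called first, only, known or untested is meant among the compounds shown, and "the series" means these compounds.

Compound 2 `C[Si](C)(C)c1cn(C[C@H](O)[C@H]2OC(=O)C(OCc3ccccc3)=C2OCc2ccccc2)nn1` gives 19200 nM in a functional assay on A549 cells (Homo sapiens) for antiproliferative activity, read by MTT assay, with a stated time of 72 h (on this read-out lower numbers stand for stronger inhibition and higher numbers for weaker inhibition), and stands highest of the two numbers measured in the series. Among the compounds with values here, compound 1 `O=C1O[C@H]([C@@H](O)Cn2cc(CNS(=O)(=O)c3ccc(Cl)cc3)nn2)C(OCc2ccccc2)=C1OCc1ccccc1` gives 2870 nM in this assay, and the step of a 6.7-fold higher number from compound 1 to compound 2 (0.83 log units; beyond the scatter) is the only measured step that bears on the question. Compound 3 `COc1ccc(-c2cn(C[C@H](O)[C@H]3OC(=O)C(OCc4ccccc4)=C3OCc3ccccc3)nn2)cc1` differs from compound 2 by a group of 8 heavy atoms (7 carbon, 1 oxygen; one six-membered aromatic ring of carbon only) in place of a group of 4 heavy atoms (3 carbon, 1 silicon; no ring), on an aromatic carbon. The measured step shows that trading an aryl-bearing group for the silicon-bearing group on this aromatic carbon weakened inhibition; compound 3 puts an aromatic ring back at that position, though with a different group than compound 1 carried. A step of similar size in the opposite direction is therefore plausible but not certain. Compound 3 is expected to reach about 7000 nM in this assay, with the range 2000 nM to 25000 nM, which means an estimated step of a 2.7-fold lower number from compound 2 to compound 3 (0.44 log units; beyond the scatter).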

Compound 3, half-maximal inhibitory concentration: 28300 nM
Compound 3: middle estimate off by 4.0-fold (0.61 log units), on the low side; the whole stated range lies below it.
By their numbers in this assay, from the lowest: compound 1; then compounds 2 and 3 (each within the scatter of the next).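

In this assay, the step of a 1.5-fold higher number from compound 2 to compound 3 (0.17 log units; within the scatter) does not separate 4-methoxyphenyl from the silicon-bearing group on this aromatic carbon, so an aromatic ring at this position is not enough to match compound 1. The step of a 9.9-fold higher number from compound 1 to compound 3 (0.99 log units; beyond the scatter) ties the lower number of compound 1 to its (((4-chlorophenyl)sulfonyl)amino)methyl group as a whole, not simply to the presence of a six-membered aromatic ring of carbon only. No supporting data are available to explain either step.

Going by these compounds, whether the lower number of compound 1 depends on the sulfonyl and amino portion or on the 4-chlorophenyl ring remains open. A plain aminomethyl group or a 4-chlorophenyl group on this aromatic carbon would help separate those two parts.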